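Moving the indole attachment point on a trimethoxyphenyl core

The source may report more compounds than this note shows. Statements on the series, on what has been measured and on what is new or still open speak of the compounds shown alone.

Measured compounds:
Compound 1 `Cn1ccc2cc(-c3cc4nccc(-c5ccc(F)cc5)n4n3)ccc21`: 3520 nM
Compound 2 `COc1cc(-c2ccnc3cc(-c4ccc5cc[nH]c5c4)nn23)cc(OC)c1OC`: 170 nM
Compound 3 `COc1ccc(-c2cc3nccc(-c4cc(OC)c(OC)c(OC)c4)n3n2)cc1[N+](=O)[O-]`: > 10000 nM

Of the compounds shown here, three have been tested in a functional assay on A549 cells (Homo sapiens) for inhibition, read by CCK-8 assay, with a stated time of 48 h (a higher number here means a weaker inhibitor, a lower number a stronger inhibitor), all built on the same fused two-ring core. In this assay compound 2 gives 170 nM, the lowest of the two numbers available. Compound 1, which carries a methylated indole and a fluorophenyl instead of the trimethoxyphenyl, gives 3520 nM, a higher number beyond the usual scatter. For compound 3 the result is a limit rather than a number: > 10000 nM, as recorded in the limit of > 10000 nM in this assay, at which 1 of the 3 values shown sits.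

Compound 4 `COc1cc(-c2ccnc3cc(-c4c[nH]c5ccccc45)nn23)cc(OC)c1OC` has not yet been measured. It contains the same atoms as compound 2, joined differently: 1H-indol-3-yl in place of 1H-indol-6-yl on an aromatic carbon. No measured pair of compounds here differs in only one place, so nothing shown tells how large such a change should be.

Compound 4 is expected to give 500 nM, within 120 nM to 3000 nM. This estimate means a step from compound 2 to compound 4 of a 2.9-fold higher number from compound 2 to compound 4 (0.47 log units; beyond the scatter), a modest weakening that may or may not exceed the scatter.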

Compound 4, half-maximal inhibitory concentration: 29 nM
Beside the measured number, compound 4's estimate is 17-fold (1.24 log units) above it; measured number below the stated range.
By their numbers in this assay, from the lowest: compound 4; then compound 2; then compound 1. At a limit, above all of these: compound 3.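

In this assay, within the data shown here, this is the first comparison in which the compounds differ in only one place, so the effect of that place can be read on its own. Keeping the same atoms and moving only the point at which the indole joins the shared core, replacing 1H-indol-6-yl with 1H-indol-3-yl on the aromatic carbon of the five-membered ring, gives a 5.9-fold lower number from compound 2 to compound 4 (0.77 log units; beyond the scatter). The two groups have the same counts of atoms, rings and hydrogen-bond donors, so the result shows that the attachment point itself matters at this position, yet nothing shown here explains why the change has this direction or size.

Only these two indole attachment points can be compared directly, and compound 1 and compound 3 each differ from compound 4 in more than one place, so neither of them isolates a further change at this position. From the compounds shown here alone, it remains open how the number would respond if a simple phenyl replaced the indole, or if the 1H-indol-3-yl group carried an amine or a carboxylic acid.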